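The compounds below may be only part of what the source reports. "The series", "measured", "known", "first", "only" and "open" are said of these compounds alone.

Measured compounds:
compound 1 `CC1(C)CC(=O)c2cc(C#N)c(N3CCN(c4ccc(F)cc4)CC3)nc2C1`, 160 nM
compound 2 `CC1(C)CC(=O)c2cc(C#N)c(N3CC=C(c4ccccc4)CC3)nc2C1`, < 1000 nM
compound 3 `CC1(C)CC(=O)c2cc(C#N)c(N3CC=C(c4ccc(F)cc4)CC3)nc2C1`, 110 nM

In an in vitro functional assay on cells for antagonist activity at metabotropic glutamate receptor 1 (Rattus norvegicus), read by inositol phosphate accumulation (on this read-out higher numbers stand for weaker inhibition and lower numbers for stronger inhibition), compound 1 gives 160 nM and compound 3 gives 110 nM; the two values lie within the scatter of each other. Compound 2 is reported only as a limit, < 1000 nM, in this assay. The difference between the core of compound 1 and that of compound 3 is not broken down here. From compound 3 to compound 2 the change is hydrogen in place of fluoro on an aromatic carbon, and the step that the limit leaves unreadable from compound 3 to compound 2 cannot be read because of the limit of < 1000 nM in this assay, at which 1 of the 3 values shown sits. Compound 4 `CC1(C)CC(=O)c2cc(C#N)c(N3CCN(c4ccccc4)CC3)nc2C1` is not yet measured in this assay; from compound 1 to compound 4 the change is hydrogen in place of fluoro on an aromatic carbon, the same change at the same kind of place. Among the measured compounds shown here, the one earlier instance gives no readable size, so the step of a 1.6-fold higher number from compound 1 to compound 4 (0.19 log units; within the scatter) is expected to be small, resting on compound 1 at 160 nM. Compound 4 is estimated at 250 nM, between 80 nM and 800 nM.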

Compound 4, half-maximal inhibitory concentration: 130 nM
Estimate against measurement, compound 4: 1.9-fold (0.28 log units) above; measured number inside the range.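

In this assay, the change from 4-fluorophenyl to phenyl on the core of compound 1 gives a 1.2-fold lower number from compound 1 to compound 4 (0.09 log units; within the scatter), so on this core the change leaves the number within the scatter. Compound 2 is reported only as a limit, < 1000 nM. The matching step from compound 3 to compound 2 cannot be read, so it remains unknown whether the result carries over from one core to the other, because only one of the two steps has a size: the limit of < 1000 nM in this assay, at which 1 of the 4 values shown sits.

Still open, from the compounds shown here alone, is whether a chloro or methoxy group at the place of the fluoro, or an amine or a carboxylic acid at the place of the nitrile, would keep the number. The carbonyl is the same in all four compounds, so these data say nothing about it.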